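A few compounds are considered here, and "the series" means these few. Any claim that something is new, unique, unknown or untested is made for them only; others in the source may bear on it.

Measured compounds and values:

compound 1 `O=C1N=C(N2N=C(c3ccccc3)CC2c2ccccc2O)S/C1=C1/C(=O)Nc2ccccc21`: 4350 nM
compound 2 `O=C1N=C(N2N=C(c3ccccc3)CC2c2ccccc2O)S/C1=C1/C(=O)Nc2ccc(Br)cc21`: 930 nM
compound 3 `COc1ccc(C2CC(c3ccccc3)=NN2C2=NC(=O)/C(=C3\C(=O)Nc4ccc(Br)cc43)S2)cc1`: 660 nM

In a functional assay on cells (Cancer cell lines, Homo sapiens) for cytotoxicity, read by sulforhodamine B assay, with a stated time of 48 h (on this read-out higher numbers stand for weaker inhibition of growth and lower numbers for stronger inhibition of growth), compound 3 holds the lowest of the three numbers, but its gap to compound 2 is within the scatter, so the two cannot be ordered; only compound 1 stands apart, beyond the scatter. Of the two measured steps, the bromo for hydrogen change gave a 4.7-fold lower number from compound 1 to compound 2 (0.67 log units; beyond the scatter), whereas the swap of the aryl group on the saturated ring carbon gave a 1.4-fold lower number from compound 2 to compound 3 (0.15 log units; within the scatter).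

Compound 4 `COc1ccc(C2=NN(C3=NC(=O)/C(=C4\C(=O)Nc5ccc(Br)cc54)S3)C(c3ccc(OC)cc3)C2)cc1` differs from compound 3 by methoxy in place of hydrogen on an aromatic carbon. Going by the values given here, no measured step touches this phenyl group. Among the compounds with values here, the only step that alters a group on the saturated ring carbon, a 1.4-fold lower number from compound 2 to compound 3 (0.15 log units; within the scatter), stayed within the scatter, and that is the nearest guide available. On that basis compound 4 is expected to sit close to compound 3, with no step beyond the scatter: a 1.1-fold lower number from compound 3 to compound 4 (0.04 log units; within the scatter). The estimate for compound 4 in this assay is 600 nM, expected between 250 nM and 1500 nM.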

Compound 4, concentration for total growth inhibition: 710 nM
Beside the measured number, compound 4's estimate is 1.2-fold (0.07 log units) below it; the measured number falls inside the stated range.
By their numbers in this assay, from the lowest: compounds 3, 4 and 2 (each within the scatter of the next); then compound 1.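

In this assay, going by these compounds alone, the phenyl to 4-methoxyphenyl change, on an aromatic carbon para to a large group, gave a 1.1-fold higher number from compound 3 to compound 4 (0.03 log units; within the scatter) and so adds a reading at a phenyl group that no earlier step touched. With the bromo kept on the core and a 4-methoxyphenyl on the saturated ring carbon, this methoxy for hydrogen change is tolerated at this place, since the number stays within the scatter. No measurement among the data explains this result.

As far as these compounds go, what an amine, a carboxylic acid or a longer chain such as butoxy would do at this same place remains open. Also open, from the compounds shown here alone, is whether methoxy at this place would read the same with hydrogen in place of the bromo, or with the 2-hydroxyphenyl group on the saturated ring carbon.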